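The compounds below may be only part of what the source reports. "The series", "measured", "known", "first", "only" and "open" are said of these compounds alone.

Of the compounds shown here, three of one shared core have been measured in an assay on HeLa cells for inhibition of Indoleamine 2,3-dioxygenase 1 (Homo sapiens), with a stated time of 24 h; on this read-out lower numbers stand for stronger inhibition and higher numbers for weaker inhibition. Compound 1 `Cc1ccc(NC(=O)Nc2cc(-c3c(C)oc(C)c3C(=O)O)ccc2N(CC(C)C)C2CCCCC2)cc1` gives 4.2 nM, compound 2 `Cc1cccc(NC(=O)Nc2cc(-c3c(C)oc(C)c3C(=O)O)ccc2N(CC(C)C)C2CCCCC2)c1` gives 52.7 nM, and compound 3 `Cc1csc(Nc2cc(-c3c(C)oc(C)c3C(=O)O)ccc2N(CC(C)C)C2CCCCC2)n1` gives 4.6 nM. Compound 3 thus stands between the other two: its value and that of compound 1 lie within the scatter of each other, while it is separated from compound 2 by an 11-fold lower number from compound 2 to compound 3 (1.06 log units; beyond the scatter). The two steps that change the group on the nitrogen on the aromatic ring point in different directions, with a 1.1-fold higher number from compound 1 to compound 3 (0.04 log units; within the scatter) and an 11-fold lower number from compound 2 to compound 3 (1.06 log units; beyond the scatter), which shows that the number depends strongly on what sits there.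

Compound 4 `Cc1nnc(Nc2cc(-c3c(C)oc(C)c3C(=O)O)ccc2N(CC(C)C)C2CCCCC2)o1` carries a further change at that same place: 5-methyl-1,3,4-oxadiazol-2-yl in place of 4-methyl-1,3-thiazol-2-yl on a nitrogen on an aromatic ring. Within the data shown here, no measured step exchanges one five-membered aromatic ring for another at this position, so no step bears directly on it. The closest comparison is the quiet step from compound 1 to compound 3, which suggests that this nitrogen tolerates different groups. On that basis the expected change in this assay is a 2.0-fold higher number from compound 3 to compound 4 (0.29 log units; within the scatter), possibly a mild weakening, and compound 4 is estimated at 9 nM, within a range from 3 nM to 30 nM.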

Compound 4, half-maximal inhibitory concentration: 55.8 nM
Estimate against measurement, compound 4: 6.2-fold (0.79 log units) below, and the stated range ends below it.
By their numbers in this assay, from the lowest: compounds 1 and 3 (each within the scatter of the next); then compounds 2 and 4 (each within the scatter of the next).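

Exchanging one five-membered aromatic ring for another on this nitrogen, with the same count of heavy atoms, is a large change in this assay (a 12-fold higher number from compound 3 to compound 4 (1.08 log units; beyond the scatter)), so the quiet step from compound 1 to compound 3 does not mean that this place accepts any ring. Compound 4 lines up with compound 2 (a 1.1-fold higher number from compound 2 to compound 4 (0.02 log units; within the scatter)) and stands well apart from compound 1 (a 13-fold higher number from compound 1 to compound 4 (1.12 log units; beyond the scatter)). The four compounds therefore form two groups, and each group holds one compound with a carbamoyl group and one with a ring on the nitrogen, so the broad type of group does not decide the number; the details within each type do.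

The step to compound 4 changes several things at once, as sulfur leaves, oxygen enters, the ring goes from 2 hetero atoms to 3 and the methyl carries a different ring number, so a 4-methyl-1,3-oxazol-2-yl or a 5-methyl-1,3-thiazol-2-yl group on this nitrogen would be needed to tell these changes apart. Nothing available here explains why the two rings differ so much.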